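The compounds below may be only part of what the source reports. "The series", "measured", "known", "first", "only" and "open" are said of these compounds alone.

Measured so far:

Compound 1, `O=S(=O)(c1cc(Cl)cc(Cl)c1)c1cnc2cc(F)ccc2c1-c1ccc(Cl)cc1`, gives 0.13 mL/min in an ADME assay on microsomes from liver (Homo sapiens) for metabolic stability, tested at 2.5 uM; a higher number here means faster removal of the compound, a lower number slower removal.
Compound 2, `O=S(=O)(c1cc(F)cc(F)c1)c1cnc2cc(F)ccc2c1-c1cccc(F)c1`, gives 0.06 mL/min in this assay.

Of these two numbers, compound 2 stands at the lower end. Compound 1 sits higher, and the gap between compound 1 and compound 2 lies beyond the usual scatter of this assay, so the two compounds are genuinely set apart.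

The step under consideration leads from compound 2 to compound 3, whose structure is `O=S(=O)(c1cc(Cl)cc(Cl)c1)c1cnc2cc(F)ccc2c1-c1cccc(F)c1`. The change is confined to one place:

3,5-dichlorophenyl in place of 3,5-difluorophenyl on a sulfonyl sulfur

For the measured compounds named here, compound 1 also carries a 3,5-dichlorophenyl on its sulfonyl sulfur, though it differs from compound 3 elsewhere, so no single measured step shows what this exchange alone does. Since compound 1 gives 0.13 mL/min while compound 2 gives 0.06 mL/min, a move upward of modest size is expected for compound 3, toward the level of compound 1 rather than beyond it. Compound 3 is estimated at 0.1 mL/min, in a range of 0.05 mL/min to 0.2 mL/min. The expected step is a 1.7-fold higher number from compound 2 to compound 3 (0.22 log units; within the scatter), likely at or just beyond the edge of scatter.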

Compound 3, intrinsic clearance in a liver preparation (reported as CLH), per the amount of preparation that the assay uses: 0.41 mL/min
For compound 3 the middle estimate is 4.1-fold (0.61 log units) below the measured one; measured number above the stated range.
By their numbers in this assay, from the lowest: compound 2; then compound 1; then compound 3.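

In this assay, putting 3,5-dichlorophenyl in place of 3,5-difluorophenyl on the sulfonyl sulfur, with the rest of the molecule unchanged, gives a 6.8-fold higher number from compound 2 to compound 3 (0.83 log units; beyond the scatter) and so shows directly that the group at this position can change how quickly a compound is removed. The other single change, 3-fluorophenyl in place of 4-chlorophenyl on an aromatic carbon, gives a 3.2-fold higher number from compound 1 to compound 3 (0.50 log units; beyond the scatter) while the 3,5-dichlorophenyl stays on the sulfur, so the rate also depends on this second site. No measurement here explains why either exchange raises the number.

The compounds shown leave open whether a phenyl ring bearing a single chlorine would give a number nearer to that of the dichlorophenyl or the difluorophenyl compound, and how this position would respond to a group without halogen, such as a methoxyphenyl or an amine. For the compounds shown here, they also leave open whether the exchange on the sulfonyl sulfur would give a step of similar size with the 4-chlorophenyl in place of the 3-fluorophenyl, since only one such pair can be read.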